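Cytotoxicity notes on a biaryl carboxylic acid series

A few compounds are considered here, and "the series" means these few. Any claim that something is new, unique, unknown or untested is made for them only; others in the source may bear on it.

Measured compounds:
compound 1 `Cc1ccc(-c2c(C)c(-c3ccc4c(c3)CCO4)c(C(OC(C)(C)C)C(=O)O)c(C)c2NS(C)(=O)=O)cc1C`: 38000 nM
compound 2 `Cc1ccc(-c2c(C)c(-c3ccc(C)c(C)c3)c(C(OC(C)(C)C)C(=O)O)c(C)c2NS(=O)(=O)C2CC2)cc1C`: 11000 nM

In an ADME assay on MT4 cells (Homo sapiens) for cytotoxicity, read by MTT assay, with a stated time of 4 days (a lower number here means that less compound is tolerated, a higher number that more compound is tolerated), compound 1 gives 38000 nM. In the same assay compound 2 gives 11000 nM, the lower of the two numbers; the gap to compound 1 lies beyond the scatter, so compound 2 is the one of which less is tolerated. The two compounds differ in more than one place, so nothing is read from their pair beyond what the two values show.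

Compound 3 `Cc1ccc(-c2c(C)c(-c3ccc(C)c(C)c3)c(C(OC(C)(C)C)C(=O)O)c(C)c2NC(=O)Nc2ccccc2)cc1C` has not yet been measured. It differs from compound 2 in one place: phenylcarbamoyl in place of cyclopropylsulfonyl on a nitrogen on an aromatic ring. Among the compounds with values here, no measured pair carries this change, so there is no step from which its effect could be read. With nothing in the data pointing either way, the expectation for compound 3 is a step of a 1.2-fold lower number from compound 2 to compound 3 (0.09 log units; within the scatter), within the scatter of compound 2 or somewhat below it. Compound 3 is expected to give 9000 nM in this assay, with a range from 3000 nM to 30000 nM.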

Compound 3, half-maximal cytotoxic concentration: 8000 nM
For compound 3 the middle estimate is 1.1-fold (0.05 log units) above the measured one, and the stated range covers the measured number.
By their numbers in this assay, from the lowest: compounds 3 and 2 (each within the scatter of the next); then compound 1.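

In this assay, the series now has its first step read at a single place: a 1.4-fold lower number from compound 2 to compound 3 (0.14 log units; within the scatter), for phenylcarbamoyl in place of cyclopropylsulfonyl on a nitrogen on an aromatic ring. At this position, the three-membered non-aromatic ring and the sulfonyl group can therefore be exchanged for a six-membered aromatic ring and a carbonyl with an added hydrogen-bond donor, and the number stays within the scatter, so this one pair shows no sensitivity of the cytotoxicity reading to the change. No supporting data bear on why the two groups read alike.

Still open, going by these compounds, is whether this holds for other kinds of group on the same nitrogen, such as a simple amine, a carboxylic acid or a longer alkyl chain, since a single pair cannot show how far the position tolerates change. Also open, on these data alone, is whether the same exchange would give a similar step on the core of compound 1, which differs from compound 2 in more than one place.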